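A few compounds are considered here, and "the series" means these few. Any claim that something is new, unique, unknown or untested is made for them only; others in the source may bear on it.

Measured so far:
compound 1, `c1ccc(-c2cnco2)c(NCC2=NCCN2)c1`: 17.4 nM in a functional assay for activation of Alpha-1A adrenergic receptor (Homo sapiens), read by calcium flux; a lower number here means that less compound is needed, a higher number that more compound is needed for the effect
compound 2, `c1csc(-c2ccccc2NCC2=NCCN2)c1`: 2.24 nM in this assay

Compound 1 stands highest of the two numbers; its nearest neighbour is compound 2, and the step of a 7.8-fold lower number from compound 1 to compound 2 (0.89 log units; beyond the scatter) shows how far a change at that aromatic carbon can move the number. Compound 3, `CC/C(=N/OC)c1ccccc1NCC1=NCCN1`, differs from compound 1 by a group of 6 heavy atoms (4 carbon, 1 nitrogen, 1 oxygen; no ring) in place of a group of 5 heavy atoms (3 carbon, 1 nitrogen, 1 oxygen; one five-membered aromatic ring with 2 hetero atoms), on an aromatic carbon. Among the compounds with values here, no measured step covers an acyclic group in this place, so the one step bears only loosely. A step of similar size in either direction, or none beyond the scatter, is expected, that is a 1.1-fold higher number from compound 1 to compound 3 (0.06 log units; within the scatter). Compound 3 is therefore estimated at 20 nM, within 5 nM to 80 nM.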

Compound 3, half-maximal effective concentration: 87.1 nM
Compound 3: middle estimate off by 4.4-fold (0.64 log units), on the low side; the measured number lies above the stated range.
By their numbers in this assay, from the lowest: compound 2; then compound 1; then compound 3.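

In this assay, the group with no ring gives a 5.0-fold higher number from compound 1 to compound 3 (0.70 log units; beyond the scatter) and a 39-fold higher number from compound 2 to compound 3 (1.59 log units; beyond the scatter), so both compounds with a five-membered aromatic ring at this aromatic carbon have lower numbers than compound 3. The range at this place is therefore wider than a 7.8-fold lower number from compound 1 to compound 2 (0.89 log units; beyond the scatter) alone suggested. No supporting data bear on what lies behind these steps.

The compounds shown leave open whether the ring itself matters or only this particular acyclic group. A phenyl ring, a simple ethyl chain or an amine at this carbon would help separate the two.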